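Ester to acid on two related cores: solubility outlook

This account rests on a few compounds, and the source may have more. Where it says the series, first, only, none or still open, it means among the compounds named here.

Measured compounds:
Compound 1, `COC(=O)c1ccccc1OCc1oc(-c2ccccc2OC)nc1C`, gives 185000 nM.
Compound 2, `COC(=O)c1cccc(OCc2oc(-c3ccccc3OC)nc2C)c1`, gives 44100 nM.
Compound 3, `COc1ccccc1-c1nc(C)c(COc2ccccc2C(=O)O)o1`, gives 402000 nM.

All three were examined in a physicochemical assay for solubility, tested at 500 uM; a lower number here means a less soluble compound, a higher number a more soluble compound. Compound 1 and compound 2 are built from the same atoms joined differently; the difference between the two cores is not broken down here. What can be said is that compound 2 has the lowest solubility of the three, and that the gap from compound 2 to compound 1 and the gap from compound 2 to compound 3 both lie beyond the usual scatter of this assay.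

Compound 1 and compound 3 differ in one place: hydrogen in place of methyl on an oxygen next to a carbonyl group. This change brought a 2.2-fold higher number from compound 1 to compound 3 (0.34 log units; beyond the scatter), a modest step in the direction of higher solubility.

Compound 4, `COc1ccccc1-c1nc(C)c(COc2cccc(C(=O)O)c2)o1`, has not yet been measured. It relates to compound 2 exactly as compound 3 relates to compound 1: hydrogen in place of methyl on an oxygen next to a carbonyl group. The place of the change is the same in both pairs, so this is the same change carried onto the core of compound 2.

Because the earlier step was a 2.2-fold higher number from compound 1 to compound 3 (0.34 log units; beyond the scatter), a step of similar size is expected from compound 2 to compound 4, namely a 2.2-fold higher number from compound 2 to compound 4 (0.34 log units; beyond the scatter). That rests on a single measured pair, so the expectation is held loosely. Compound 4 is therefore estimated to give about 97000 nM in this assay, most likely between 50000 nM and 200000 nM.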

Compound 4, solubility: 423000 nM
Estimate against measurement, compound 4: 4.4-fold (0.64 log units) below; the measured number lies above the stated range.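

In this assay, the change from methoxycarbonyl to carboxy on the core of compound 2 brought a 9.6-fold higher number from compound 2 to compound 4 (0.98 log units; beyond the scatter) and the same change on the core of compound 1 brought a 2.2-fold higher number from compound 1 to compound 3 (0.34 log units; beyond the scatter) so the number went up on both cores, by a step beyond the usual scatter each time. The direction therefore carried from one core to the other, but the size did not, and the step measured on one core proved a poor guide to the size of the step on the other. These two pairs show no general rule for further cores, and nothing shown here explains why the same change gave steps of different size on these two cores.

The compounds shown leave open how the number would respond if the methyl on that oxygen gave way to a longer chain such as ethyl, or if the carboxy gave way to another group such as a primary amide or a nitrile. They also leave open whether the change from methoxycarbonyl to carboxy would raise the number on a third core, and by how much.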